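Hydroxy added to the chlorophenyl arm of compound 3

This account rests on a few compounds, and the source may have more. Where it says the series, first, only, none or still open, it means among the compounds named here.

Working notes on the shared core with two substituted arms. Going by the values given here, compound 1 `COc1cccc(/C=C2\CCC/C(=C\c3ccccc3Cl)C2=O)c1OC` gives 10300 nM in a functional assay on SW-620 cells (Homo sapiens) for cytotoxicity, read by MTT assay, with a stated time of 72 h (a lower number here means a stronger inhibitor, a higher number a weaker inhibitor), and compound 2 `COc1cccc(/C=C2\CCC/C(=C\c3ccccc3Br)C2=O)c1OC` gives 12100 nM; the one single-point step measured so far, a 1.2-fold higher number from compound 1 to compound 2 (0.07 log units; within the scatter), is a halogen exchange and changes nothing beyond the scatter. Compound 3 `COc1ccc(/C=C2\CCC/C(=C\c3cccc(Cl)c3)C2=O)cc1OC` gives 5100 nM, the lowest of the three numbers, with compound 1 beyond the scatter above it and compound 2 further still.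

Compound 4 `COc1ccc(/C=C2\CCC/C(=C\c3ccc(O)c(Cl)c3)C2=O)cc1OC` differs from compound 3 by hydroxy in place of hydrogen on an aromatic carbon. Among the compounds with values here, no measured step adds a hydroxy group, and the only step available concerns a different exchange on the other arm that stayed within the scatter, so nothing here points to a large shift in this assay in either direction. A step within or near the scatter is therefore expected, a 1.1-fold lower number from compound 3 to compound 4 (0.05 log units; within the scatter). Compound 4 is expected to give 4500 nM in this assay, with a range from 1800 nM to 11000 nM.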

Compound 4, half-maximal inhibitory concentration: 7100 nM
The estimate for compound 4 lay 1.6-fold (0.20 log units) below the measured number; measured number inside the range.
By their numbers in this assay, from the lowest: compounds 3, 4, 1 and 2 (each within the scatter of the next, the first and the last beyond it).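

Going from 3-chlorophenyl to 3-chloro-4-hydroxyphenyl keeps the number in this assay within the scatter (a 1.4-fold higher number from compound 3 to compound 4 (0.14 log units; within the scatter)), so this place, ortho to a chloro group and para to a large group, accepts a hydroxy without a shift that can be read in this assay. Going by these compounds alone, this is the first step that adds a heavy atom instead of exchanging one, and like the halogen exchange (a 1.2-fold higher number from compound 1 to compound 2 (0.07 log units; within the scatter)) it stays within the scatter. No supporting measurement is at hand that would explain this result.

Going by these compounds, whether this place stays as undemanding for other groups remains open, since an amine or a carboxylic acid here would test a larger change than hydroxy. Also open, on these data alone, is whether hydroxy gives the same small step on an arm without the chloro group.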